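The source may report more compounds than this note shows. Statements on the series, on what has been measured and on what is new or still open speak of the compounds shown alone.

For the measured compounds named here, in a physicochemical assay for solubility, read by HPLC, measured as thermodynamic solubility, with a stated time of 4 h, at pH 6.8 (on this read-out lower numbers stand for lower solubility and higher numbers for higher solubility), compound 1 `Cc1ccc(Oc2ccc3nc(COc4cccc(C(=O)O)c4)n(C)c3c2)nc1C` gives 190 ug/mL, and compound 2 `Cc1cc(F)cnc1Oc1ccc2nc(COc3cccc(C(=O)O)c3)n(C)c2c1` gives 14 ug/mL, the lowest of the two numbers so far; that gap is a 14-fold lower number from compound 1 to compound 2 (1.13 log units; beyond the scatter). Compound 3 `Cc1cc(Cl)cnc1Oc1ccc2nc(COc3cccc(C(=O)O)c3)n(C)c2c1` differs from compound 2 by chloro in place of fluoro on an aromatic carbon. Going by the values given here, no measured step exchanges these two halogens; the only step on the same ring, from compound 1 to compound 2, was large but involved a different pair of groups, so it bears only loosely here. Compound 3 is expected to show a step of a 2.0-fold lower number from compound 2 to compound 3 (0.30 log units; within the scatter) in this assay, a modest fall or none beyond the scatter. Compound 3 is estimated at 7 ug/mL, within 2 ug/mL to 20 ug/mL.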

Compound 3, solubility: 3.9 ug/mL
For compound 3 the middle estimate is 1.8-fold (0.25 log units) above the measured one; low and high end bracket the measured number.
By their numbers in this assay, from the lowest: compound 3; then compound 2; then compound 1.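

At this position the halogen itself counts in this assay: chloro in place of fluoro on an aromatic carbon gives a 3.6-fold lower number from compound 2 to compound 3 (0.56 log units; beyond the scatter) and so moves the number beyond the scatter. The 5-chloro-3-methylpyridin-2-yl group also stands further from the 5,6-dimethylpyridin-2-yl group than the fluoro analogue does, with a 49-fold lower number from compound 1 to compound 3 (1.69 log units; beyond the scatter) as the wider gap. Nothing here gives a measured reason for either step.

Open, going by these compounds, is whether an amine or a methoxy group on this aromatic carbon would sit with the halogens or nearer compound 1. Also open, on these data alone, is whether the fluoro-to-chloro step holds on other cores.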